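Nitrophenyl in Place of Methylphenyl: Expected Cell Growth Inhibition

The source may report more compounds than this note shows. Statements on the series, on what has been measured and on what is new or still open speak of the compounds shown alone.

Compound 1 `NC(=O)c1c(NC(=O)c2ccccc2Cl)sc2c1CCN(Cc1ccc(Cl)cc1Cl)C2` carries a 2-chlorophenyl on the carbonyl carbon of its amide. In a functional assay on HeLa cells (Homo sapiens) for antiproliferative activity, with a stated time of 24 h (on this read-out lower numbers stand for stronger inhibition and higher numbers for weaker inhibition), compound 1 gives 21100 nM. Compound 2 `Cc1ccc(C(=O)Nc2sc3c(c2C(N)=O)CCN(Cc2ccc(Cl)cc2Cl)C3)cc1` differs from it in one place, a 4-methylphenyl in place of that 2-chlorophenyl. Compound 2 reaches only the limit of this assay, > 50000 nM, so no exact number is known for it. The change an at least 2.3-fold higher number from compound 1 to compound 2 (0.37 log units; beyond the scatter) is therefore a loss of activity whose full size cannot be read, because it runs into (the limit of > 50000 nM in this assay, at which 1 of the 2 values shown sits). Compound 3 `NC(=O)c1c(NC(=O)c2cccc([N+](=O)[O-])c2)sc2c1CCN(Cc1ccc(Cl)cc1Cl)C2` is not yet measured. Its change from compound 2 is 3-nitrophenyl in place of 4-methylphenyl on a carbonyl carbon. For the measured compounds named here, only one measured step exists, and it alters the same aryl ring: the step from compound 1 to compound 2 was at least modest and made the number larger. That step says nothing directly about a nitro group, and compound 2 itself is only a limit, so the footing for a prediction is thin. Compound 3 is estimated at 45000 nM, with a likely range from 12000 nM to 150000 nM. The expected step of an at least 1.1-fold lower number from compound 2 to compound 3 (0.04 log units; that floor lies within the scatter) is thus small and uncertain, and a further limit is about as likely as a number.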

Compound 3, half-maximal inhibitory concentration: 33000 nM
Compound 3: the middle estimate sits 1.4-fold (0.13 log units) above what was measured; measured number inside the range.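

For the compounds shown here, with a 3-nitrophenyl on the carbonyl carbon, this assay returns a number rather than a limit, so the 2-chlorophenyl of compound 1 is no longer the only group at this position with a readable result. The comparison of these two groups gives a 1.6-fold higher number from compound 1 to compound 3 (0.19 log units; within the scatter), so compound 1 and compound 3 cannot be told apart on this read-out, even though the two groups differ in their atoms and in where they are attached on the ring. The comparison with the 4-methylphenyl gives an at least 1.5-fold lower number from compound 2 to compound 3 (0.18 log units; that floor lies within the scatter), and this floor does not settle whether the two compounds truly differ, because the value for compound 2 is not a number but an assay limit: the limit of > 50000 nM in this assay, at which 1 of the 3 values shown sits.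

The compounds shown leave open what a 3-methylphenyl or a 4-nitrophenyl would give, and such a pair would help separate the effect of the group itself from that of its place on the ring. Going by these compounds, what an amine or a carboxylic acid on this same ring would give is also open, as is whether any group at this position can reach a much lower number.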